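From a methoxypropyl to a butyl oxime ether

The compounds below may be only part of what the source reports. "The series", "measured", "known", "first", "only" and "open" are said of these compounds alone.

Of the compounds shown here, three built on one shared core have been measured. Compound 1 `CO/N=C/c1c(N)ncnc1Oc1ccc2cccnc2c1` gives 2620 nM in a functional assay on HCT-116 cells (Homo sapiens) for antiproliferative activity; a higher number here means a weaker inhibitor, a lower number a stronger inhibitor. Compound 2 `COCCCO/N=C/c1c(N)ncnc1Oc1ccc2[nH]c(C)cc2c1F` gives 438 nM in this assay, and compound 3 `CO/N=C/c1c(N)ncnc1Oc1ccc2[nH]cc(C)c2c1` gives 385 nM. Among these three numbers compound 2 stands second highest; its nearest neighbour is compound 3, whose value lies within the scatter of it, while compound 1 lies furthest away, beyond the scatter. Among the compounds with values here, no pair of measured compounds differs in a single place, so none of these gaps can be read as one structural step.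

Compound 4 `CCCCO/N=C/c1c(N)ncnc1Oc1ccc2[nH]c(C)cc2c1F` has not yet been measured. It differs from compound 2 in one place: methyl in place of methoxy on a saturated chain carbon, three bonds along the chain from an oxygen on an unsaturated carbon. The change reaches only the end of the chain on the oxime ether, turning 3-methoxypropyl into butyl, and leaves the rest of compound 2 untouched. Nothing measured here speaks directly to this change, so the expected step from compound 2 to compound 4 is one that stays within the scatter, with no clear direction, and it is written as a 1.1-fold lower number from compound 2 to compound 4 (0.04 log units; within the scatter). Compound 4 is estimated at 400 nM in this assay, within a range from 150 nM to 1100 nM.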

Compound 4, half-maximal inhibitory concentration: 1000 nM
Beside the measured number, compound 4's estimate is 2.5-fold (0.40 log units) below it; the range from low to high includes it.
By their numbers in this assay, from the lowest: compounds 3 and 2 (each within the scatter of the next); then compound 4; then compound 1.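

In this assay, within the data shown here, the exchange of 3-methoxypropyl for butyl gives a 2.3-fold higher number from compound 2 to compound 4 (0.36 log units; beyond the scatter) and so provides the first comparison in this set that can be read as a single structural step. It shows that this position on the oxime ether chain is not indifferent to what it carries: with the rest of compound 2 unchanged, methyl in place of methoxy gives a weaker inhibitor, although the step is modest. Nothing available accounts for this step.

This single pair cannot separate the loss of the methoxy oxygen from the change in the group as a whole, and it cannot show whether the same step would appear on the other substituted cores of compound 1 or compound 3. How a hydroxyl, an amine or a longer chain such as 4-methoxybutyl would read at this position remains open, so the compounds shown establish one step here rather than a trend along the chain.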